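The source may hold more compounds than are shown below. What is called first, only, known or untested is meant among the compounds shown, and "the series" means these compounds.

Compound 1 `COc1ccc(-c2cnc(NC(=O)c3ncc[nH]3)n2C)cc1` is the starting point, and it has been tested in a toxicity assay on THP-1 cells (Homo sapiens) for inhibition; a higher number here means that more compound is tolerated, a lower number that less compound is tolerated. There compound 1 gives > 100000 nM, which is a limit of the assay and not a number. Among the compounds with values here, compound 2 `COc1ccc(-c2cn(C)c(NC(=O)c3ccc(F)cc3)n2)cc1` is the only other compound measured so far. In this assay compound 2 gives > 50000 nM, and this too is a limit.

Compound 3 `COc1ccc(-c2cnc(NC(=O)CCc3ccccc3)n2C)cc1` keeps the core of compound 1, but phenethyl takes the place of 1H-imidazol-2-yl on a carbonyl carbon: phenethyl in place of 1H-imidazol-2-yl on a carbonyl carbon. Within the data shown here, no two measured compounds differ in just one place, so the data offer no measured step as a guide for this change. With limits alone to go on, any forecast is loose. The expected change an at least 2.5-fold lower number from compound 1 to compound 3 (0.39 log units; beyond the scatter) is a modest move towards a lower number in this assay, and it may not exceed the usual scatter. Compound 3 could also end up reported only as a limit. For compound 3 the estimated value is 40000 nM, with an expected range from 10000 nM to 100000 nM.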

Compound 3, half-maximal cytotoxic concentration: > 100000 nM
Compound 3 was reported as a limit (the forecaster's own chance of this, stated with the estimate: 55%); middle value at least 2.5-fold (0.39 log units) from the limit.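

The step from compound 1 to compound 3 cannot be read, because both are reported only as limits in this assay, and a limit is not a number: the limit of > 100000 nM in this assay, at which 2 of the 3 values shown sit.

The compounds shown leave open at what concentration any of them harms these cells, and whether phenethyl in place of 1H-imidazol-2-yl changes that concentration at all.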